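A few compounds are considered here, and "the series" means these few. Any claim that something is new, unique, unknown or untested is made for them only; others in the source may bear on it.

Measured compounds in a functional assay on SW1573 cells (Homo sapiens) for cytotoxicity, read by sulforhodamine B assay, with a stated time of 72 h; on this read-out lower numbers stand for stronger inhibition and higher numbers for weaker inhibition:
compound 1 `CCCCC(=O)Nc1ccn([C@@H]2CO[C@H](CO)O2)c(=O)n1`: 9130 nM
compound 2 `CCCCCCCCCCCCCCCCCCCC(=O)Nc1ccn([C@@H]2CO[C@H](CO)O2)c(=O)n1`: 150 nM
compound 3 `CCCCCCCCCCCCCCCCCCCCCC(=O)Nc1ccn([C@@H]2CO[C@H](CO)O2)c(=O)n1`: 900 nM

Compound 1 stands at the highest number of the three; compound 3 and compound 2 both give lower numbers, compound 2 the lowest. Going by the values given here, the one step between compounds that differ in a single place, a 6.0-fold higher number from compound 2 to compound 3 (0.78 log units; beyond the scatter), concerns the far end of a long saturated chain and says nothing about the carbonyl substituent itself.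

Compound 4 `COc1ccc(C(=O)Nc2ccn([C@@H]3CO[C@H](CO)O3)c(=O)n2)cc1` is compound 1 with 4-methoxyphenyl in place of butyl on a carbonyl carbon. Among the compounds with values here, no measured pair tests an aromatic group, or a methoxy group, at this place; the series so far only varies chain length. Within the data shown here, the step from compound 1 to compound 4 therefore has no direct precedent, and the direction is open. The expectation is a small step, a 1.5-fold lower number from compound 1 to compound 4 (0.18 log units; within the scatter), leaning toward a lower number only because compound 1 gives 9130 nM, the highest of the set, leaving more room downward than upward. Compound 4 is estimated at 6000 nM, with a range of 1500 nM to 20000 nM.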

Compound 4, half-maximal inhibitory concentration: 10000 nM
The estimate for compound 4 lay 1.7-fold (0.22 log units) below the measured number; the measured number falls inside the stated range.
By their numbers in this assay, from the lowest: compound 2; then compound 3; then compounds 1 and 4 (each within the scatter of the next).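

In this assay the change to 4-methoxyphenyl in place of butyl on a carbonyl carbon gives a 1.1-fold higher number from compound 1 to compound 4 (0.04 log units; within the scatter) and so does not separate the two groups, although the entering group brings an aromatic ring and a hydrogen-bond acceptor that butyl lacks. Going by these compounds alone, this is the only reading of an aromatic group at this place, and it shows that this group does not give the lower numbers seen with the long chains of compound 2 and compound 3. No measurement shown bears on why the two groups read alike.

Open, as far as these compounds go, is whether a phenyl without the methoxy group, or a decyl chain, on this carbonyl carbon would read apart from compound 1. Also open, from the compounds shown here alone, is whether an aromatic group carrying a long chain could approach compound 2 at 150 nM in this assay.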